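This account rests on a few compounds, and the source may have more. Where it says the series, first, only, none or still open, it means among the compounds named here.

Compound 1, `CCNc1cnc2ccc(-c3cnc(OC)c(NS(=O)(=O)c4ccc(F)cc4F)c3)cc2c1OC`, is a sulfonamide carrying an ethylamino group on its core. In a functional assay on PC-3 cells (Homo sapiens) for antiproliferative activity, read by sulforhodamine B assay, with a stated time of 72 h (a lower number here means a stronger inhibitor, a higher number a weaker inhibitor), compound 1 gives 4820 nM. Going by the values given here, the only other measured compound is compound 2, `COc1ncc(-c2ccc3ncc(NCc4ccc(C(F)(F)F)cc4)c(OC)c3c2)cc1NS(=O)(=O)c1ccc(F)cc1F`, in which a 4-(trifluoromethyl)phenyl replaces a methyl on the saturated chain carbon bound to that ring nitrogen; in this assay compound 2 gives 2880 nM. The step of a 1.7-fold lower number from compound 1 to compound 2 (0.22 log units; within the scatter) is within the scatter, so the two values cannot be ordered, and compound 1 simply sits alongside compound 2.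

Compound 3, `COc1ncc(-c2ccc3ncc(NC(C)=O)c(OC)c3c2)cc1NS(=O)(=O)c1ccc(F)cc1F`, has not been measured in this assay. It differs from compound 1 by acetyl in place of ethyl on a nitrogen on an aromatic ring. Among the compounds with values here, no measured step touches this change: the one step on record, from compound 1 to compound 2, alters the substituent on the chain carbon and leaves the ring nitrogen's ethyl intact. With nothing to lean on, compound 3 is expected to land near compound 1, with a step of a 1.2-fold higher number from compound 1 to compound 3 (0.10 log units; within the scatter) assigned only as a wide guess. The value of compound 3 in this assay is therefore estimated at 6000 nM, between 2500 nM and 15000 nM.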

Compound 3, half-maximal inhibitory concentration: 1240 nM
For compound 3 the middle estimate is 4.8-fold (0.68 log units) above the measured one, and the stated range ends above it.
By their numbers in this assay, from the lowest: compound 3; then compounds 2 and 1 (each within the scatter of the next).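

In this assay, the substituent on the nitrogen on an aromatic ring can move the number beyond the scatter: acetyl in place of ethyl gives a 3.9-fold lower number from compound 1 to compound 3 (0.59 log units; beyond the scatter), whereas the earlier change, a 1.7-fold lower number from compound 1 to compound 2 (0.22 log units; within the scatter), stayed within it. Acetyl in place of 4-(trifluoromethyl)benzyl gives a 2.3-fold lower number from compound 2 to compound 3 (0.37 log units; beyond the scatter), so compound 3, the acetamido compound, has the lowest number of the three, with its steps to both others beyond the scatter, though each is modest. Nothing available bears on why the change from ethylamino to acetamido lowers the number in this way.

The three compounds leave open whether the lower number goes with a carbonyl on this nitrogen in general or with acetyl alone: a longer acyl chain such as propionyl, a benzoyl group or a urea would separate the two. Going by these compounds, they also give no reading for the free amine or a sulfonamide at this nitrogen, so how far the trend extends beyond acetyl remains unknown.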